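Biaryl substituent changes in a fatty acid receptor agonist series

The source may hold more compounds than are shown below. What is called first, only, known or untested is meant among the compounds shown, and "the series" means these compounds.

Compound 2 `Cn1ccnc1[C@@H](CC(=O)O)c1ccc(OCc2cccc(-c3ccc(Cl)cc3Cl)c2)cc1` gives 69 nM in an assay on CHO cells for agonist activity at Free fatty acid receptor 1 (Homo sapiens), read by luminescence, with a stated time of 20 s, in the presence of a further agent that is not named here (a lower number here means that less compound is needed, a higher number that more compound is needed for the effect), and stands second highest of the three numbers: compound 3 `Cc1cccc(C)c1-c1cccc(COc2ccc([C@H](CC(=O)O)c3nccn3C)cc2)c1` at 58 nM lies within the scatter of it, while compound 1 `COc1ccc(-c2cccc(COc3ccc([C@H](CC(=O)O)c4nccn4C)cc3)c2)cc1` at 440 nM lies beyond it. The steps of a 6.4-fold lower number from compound 1 to compound 2 (0.80 log units; beyond the scatter) and a 7.6-fold lower number from compound 1 to compound 3 (0.88 log units; beyond the scatter) place both substituted rings well apart from compound 1, whereas a 1.2-fold lower number from compound 2 to compound 3 (0.08 log units; within the scatter) shows no separation between them. Compound 4 `Cn1ccnc1[C@@H](CC(=O)O)c1ccc(OCc2cccc(-c3ccccc3Cl)c2)cc1` carries hydrogen in place of chloro on an aromatic carbon. Among the measured compounds shown here, no measured step covers this change, and no measured compound carries a 2-chlorophenyl. Because a 1.2-fold lower number from compound 2 to compound 3 (0.08 log units; within the scatter) stays within scatter between two differently substituted rings, only a small step of a 1.6-fold higher number from compound 2 to compound 4 (0.20 log units; within the scatter) is expected here. Compound 4 is estimated at 110 nM, within 40 nM to 300 nM.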

Compound 4, half-maximal effective concentration: 43 nM
For compound 4 the middle estimate is 2.6-fold (0.41 log units) above the measured one, and the stated range covers the measured number.
By their numbers in this assay, from the lowest: compounds 4, 3 and 2 (each within the scatter of the next); then compound 1.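

Loss of the chloro para to a large group gives a 1.6-fold lower number from compound 2 to compound 4 (0.21 log units; within the scatter) and does not separate the 2-chlorophenyl ring from the 2,4-dichlorophenyl ring. The 2-chlorophenyl ring also stays level with the 2,6-dimethylphenyl ring, with a 1.3-fold lower number from compound 3 to compound 4 (0.13 log units; within the scatter), while a 10-fold lower number from compound 1 to compound 4 (1.01 log units; beyond the scatter) keeps the 4-methoxyphenyl ring of compound 1 apart. No measurement shown accounts for these steps.

Still open, on these data alone, is whether the unsubstituted phenyl ring stays level with compound 4 or moves toward compound 1. Also open, as far as these compounds go, is where a ring bearing an amine or a nitrile in place of the chloro would fall.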